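Methoxy to Methyl on the Chain of Compound 1

This account rests on a few compounds, and the source may have more. Where it says the series, first, only, none or still open, it means among the compounds named here.

Of the compounds shown here, three of one series have been tested in a functional assay on the whole organism (strain Swiss) with Mus musculus as the target, in the maximal electroshock model, with a stated time of 0.25 h; on this read-out higher numbers stand for an effect only at larger amounts of compound and lower numbers for an effect already at smaller amounts. Compound 1 `COCC(C(=O)N1CCN(c2cccc(C(F)(F)F)c2)CC1)N1C(=O)CCC1=O` gives 58.1 mg/kg, compound 2 `CC(C(=O)N1CCN(c2ccccc2C(F)(F)F)CC1)N1C(=O)CCC1=O` gives 75.5 mg/kg, and compound 3 `CC(C(=O)N1CCN(c2cccc(F)c2)CC1)N1C(=O)CCC1=O` gives 137 mg/kg. Compound 1 stands at the low end of these three numbers; compound 2 lies within the usual scatter of it, while compound 3 lies beyond that scatter.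

Compound 4 `CCC(C(=O)N1CCN(c2cccc(C(F)(F)F)c2)CC1)N1C(=O)CCC1=O` differs from compound 1 by methyl in place of methoxy on a saturated chain carbon, two bonds along the chain from an amide-type nitrogen in a ring and a carbonyl carbon. Among the measured compounds shown here, no single-point step between measured compounds shows what such a change does here. Compound 4 is therefore expected to sit close to compound 1, with a step of a 1.0-fold higher number from compound 1 to compound 4 (0.01 log units; within the scatter) that is not expected to go beyond the scatter in either direction. In this assay compound 4 is estimated at 60 mg/kg, in a range from 30 mg/kg to 120 mg/kg.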

Compound 4, dose for half-maximal effect: 58.9 mg/kg
The estimate for compound 4 lay 1.0-fold (0.01 log units) above the measured number; the range from low to high includes it.
By their numbers in this assay, from the lowest: compounds 1, 4, 2 and 3 (each within the scatter of the next, the first and the last beyond it).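

In this assay, methyl in place of methoxy on this saturated chain carbon gives a 1.0-fold higher number from compound 1 to compound 4 (0.01 log units; within the scatter). This first single-point step in the series shows that the methoxy group, with its hydrogen-bond acceptor, can give way to methyl here without a change beyond the scatter. Nothing shown explains why the two compounds read alike.

As far as these compounds go, it remains open whether a longer chain such as propyl, a hydroxymethyl group or an amine on this carbon would also stay within the scatter. From the compounds shown here alone, whether the same change would read alike with the other groups on the shared core also remains open.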